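The compounds below may be only part of what the source reports. "The series", "measured", "known", "first", "only" and "open" are said of these compounds alone.

Measured so far:
Compound 1, `C/C(=C\COC(=O)Nc1ccccc1)C1=CC(=O)C(C)(C)O1`. In a functional assay on MOLT-4F cells (Homo sapiens) for inhibition (a lower number here means a stronger inhibitor, a higher number a weaker inhibitor), compound 1 gives > 200 ug/mL, which is a limit of the assay rather than a number.
Compound 2, `C/C(=C\COC(=O)NC(C)C)C1=CC(=O)C(C)(C)O1`. In this assay compound 2 gives 6.6 ug/mL.
Compound 3, `COc1ccc(/C=C/C=C(\C)C2=CC(=O)C(C)(C)O2)cc1`. In this assay compound 3 gives 10 ug/mL.

Compound 3 thus holds the higher of the two numbers available, with compound 2 nearest and within the scatter of it. Compound 4, `C/C(=C\C=C\c1ccccc1)C1=CC(=O)C(C)(C)O1`, differs from compound 3 by hydrogen in place of methoxy on an aromatic carbon. Among the measured compounds shown here, the only measured step, an at least 30-fold lower number from compound 1 to compound 2 (1.48 log units; beyond the scatter), concerns a group on an amide-type nitrogen, not a substituent on the aromatic ring, so no measured step bears on the present change. Without a relevant precedent, compound 4 is expected to stay within the scatter of compound 3, estimated at 15 ug/mL (range 5 ug/mL to 45 ug/mL), which means an expected step of a 1.5-fold higher number from compound 3 to compound 4 (0.18 log units; within the scatter).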

Compound 4, half-maximal inhibitory concentration: 14 ug/mL
Estimate against measurement, compound 4: 1.1-fold (0.03 log units) above; the range from low to high includes it.
By their numbers in this assay, from the lowest: compounds 2, 3 and 4 (each within the scatter of the next, the first and the last beyond it). At a limit, above all of these: compound 1.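

Hydrogen in place of methoxy on an aromatic carbon, para to a large group, gives a 1.4-fold higher number from compound 3 to compound 4 (0.15 log units; within the scatter) in this assay. Among the compounds shown here, the methoxy is therefore not required to hold inhibition at this level, and this is the first reading on the aromatic ring, as the earlier step concerned only the amide-type nitrogen. Nothing measured here speaks to why this step is so small.

Going by these compounds, whether an amine or a carboxylic acid on this aromatic carbon would stay within the scatter of compound 3 remains open. So does the effect of a longer chain in place of methoxy.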